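This account rests on a few compounds, and the source may have more. Where it says the series, first, only, none or still open, it means among the compounds named here.

In a functional assay on MCF7 cells (Homo sapiens) for antiproliferative activity, read by MTT assay, with a stated time of 72 h (on this read-out higher numbers stand for weaker inhibition and lower numbers for stronger inhibition), compound 1 `CC/C=C/C(=O)Nc1cc2c(N3CCc4ccccc43)ncnc2cc1OC` gives 4030 nM, the lower of the two numbers seen so far. Compound 2 `CC/C=C/C(=O)Nc1cc2c(N3CCc4ccccc43)ncnc2cc1O[C@@H]1CCOC1` gives 8840 nM in this assay, and the move from compound 1 to compound 2 is a 2.2-fold higher number from compound 1 to compound 2 (0.34 log units; beyond the scatter). Compound 3 `COc1cc2ncnc(N3CCc4ccccc43)c2cc1NC(=O)/C=C/CN1CCCC1` differs from compound 1 by pyrrolidin-1-yl in place of methyl on a saturated chain carbon bound to a double-bonded chain carbon. Among the compounds with values here, no measured step touches this chain position, so there is no direct guide to the size of this step in this assay. A step of a 1.6-fold lower number from compound 1 to compound 3 (0.21 log units; within the scatter) is expected, with wide uncertainty. Compound 3 is estimated at 2500 nM, plausibly from 800 nM to 8000 nM.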

Compound 3, half-maximal inhibitory concentration: 1510 nM
Beside the measured number, compound 3's estimate is 1.7-fold (0.22 log units) above it, within the range that was stated.
By their numbers in this assay, from the lowest: compound 3; then compound 1; then compound 2.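

Within the data shown here, this chain position had not been varied in the earlier compounds, and it does affect the result in this assay: pyrrolidin-1-yl in place of methyl gives a 2.7-fold lower number from compound 1 to compound 3 (0.43 log units; beyond the scatter) and moves the number toward stronger inhibition. The change at this position is therefore larger than the scatter between repeated measurements. Nothing available here explains the change.

From the compounds shown here alone, it remains open whether this shift depends on the pyrrolidine ring itself or would also appear with another amine, such as dimethylamino, piperidin-1-yl or morpholin-4-yl. Going by these compounds, the effect of pyrrolidin-1-yl alongside the oxolan-3-yl group of compound 2 also remains open.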